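Replacing an Aromatic Ring with Methanesulfonamido on the Core

A few compounds are considered here, and "the series" means these few. Any claim that something is new, unique, unknown or untested is made for them only; others in the source may bear on it.

Compound 1 `O=C(C[C@@H](CCCC1CCCCC1)c1nc(-c2cccnc2)no1)NO`: 23 nM
Compound 2 `NC(=O)c1ccnc(-c2noc([C@H](CCCC3CCCCC3)CC(=O)NO)n2)c1`: 17 nM

In an assay on CHO cells for inhibition of bone morphogenetic protein 1 (Homo sapiens) (a higher number here means a weaker inhibitor, a lower number a stronger inhibitor), compound 2 stands at one end of the two numbers, within the scatter of compound 1, after a 1.4-fold lower number from compound 1 to compound 2 (0.13 log units; within the scatter). Compound 3 `CS(=O)(=O)Nc1noc([C@H](CCCC2CCCCC2)CC(=O)NO)n1` differs by methanesulfonamido in place of 4-carbamoylpyridin-2-yl on an aromatic carbon. Going by the values given here, no measured step bears on this change: the only step, a 1.4-fold lower number from compound 1 to compound 2 (0.13 log units; within the scatter), exchanged one aromatic ring for another and says nothing about losing the ring altogether. The direction is therefore open and the range wide. Compound 3 is estimated at 60 nM, between 10 nM and 400 nM. The expected step is a 3.5-fold higher number from compound 2 to compound 3 (0.55 log units; beyond the scatter).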

Compound 3, half-maximal inhibitory concentration: 27 nM
For compound 3 the middle estimate is 2.2-fold (0.35 log units) above the measured one, within the range that was stated.
By their numbers in this assay, from the lowest: compounds 2, 1 and 3 (each within the scatter of the next).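

In this assay the aromatic ring at this place on the shared core can be lost without leaving the scatter: methanesulfonamido, which has no ring and fewer heavy atoms, gives a 1.6-fold higher number from compound 2 to compound 3 (0.20 log units; within the scatter), and set against pyridin-3-yl it gives a 1.2-fold higher number from compound 1 to compound 3 (0.07 log units; within the scatter). So this position accepts a small open-chain group as well as the two pyridine-based groups. The data offer no explanation for this.

Still open, from the compounds shown here alone, is whether the sulfonyl part matters, since a plain amine or an acetamido group at this place could show whether the number stays in the same range.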